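This account rests on a few compounds, and the source may have more. Where it says the series, first, only, none or still open, it means among the compounds named here.

Measured compounds in a functional assay on MDA-MB-231 cells (Homo sapiens) for inhibition, read by MTT assay, with a stated time of 72 h; on this read-out higher numbers stand for weaker inhibition and lower numbers for stronger inhibition:
compound 1 `COc1ccc(C=c2s/c(=C3\C(=O)Nc4cc(F)ccc43)n(CCN(C)C)c2=O)cc1`, 2090 nM;
compound 2 `CN(C)CCN1C(=O)/C(=C/c2ccc(O)cc2)SC1=S`, 84200 nM;
compound 3 `Cc1ccc2c(c1)/C(=c1/sc(=Cc3ccc(F)c(F)c3)c(=O)n1CCN(C)C)C(=O)N2`, a limit only, > 200000 nM.

Compound 1 gives the lowest of the two numbers, and compound 2 stands well beyond the scatter from it. Compound 3 sits at the limit of this assay (the limit of > 200000 nM in this assay, at which 1 of the 3 values shown sits), so no number is known for it. The compound not yet measured is compound 4 `CN(C)CCn1c(=O)c(=Cc2ccc(F)c(F)c2)s/c1=C1\C(=O)Nc2cc(F)ccc21`, which differs from compound 1 in one place: 3,4-difluorophenyl in place of 4-methoxyphenyl on a double-bonded chain carbon bound to an aromatic carbon. For the measured compounds named here, no measured pair carries this change by itself, so its size can only be expected. Compound 3, which also carries a 3,4-difluorophenyl, gives only the limit > 200000 nM. Compound 1, with its 4-methoxyphenyl, gives 2090 nM. From these two results, a move toward weaker inhibition, beyond the scatter, is expected for a 3.8-fold higher number from compound 1 to compound 4 (0.58 log units; beyond the scatter). Compound 4 is therefore estimated at 8000 nM, within 2000 nM to 40000 nM.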

Compound 4, half-maximal inhibitory concentration: 25000 nM
Estimate against measurement, compound 4: 3.1-fold (0.49 log units) below, within the range that was stated.
By their numbers in this assay, from the lowest: compound 1; then compound 4; then compound 2. At a limit, above all of these: compound 3.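

In this assay, the change from 4-methoxyphenyl to 3,4-difluorophenyl on a double-bonded chain carbon bound to an aromatic carbon can now be read by itself, and it gives a 12-fold higher number from compound 1 to compound 4 (1.08 log units; beyond the scatter). This place on the core of compound 1 therefore does not tolerate the two groups equally, and the 4-methoxyphenyl gives the stronger inhibition of this pair. Nothing measured here accounts for the size of this step. As far as these compounds go, whether a plain phenyl or a 3,4-dimethoxyphenyl at this place would give a number lower than that of compound 1 remains open.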